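A few compounds are considered here, and "the series" means these few. Any claim that something is new, unique, unknown or untested is made for them only; others in the source may bear on it.

Compound 1 `N#C/C(=C\c1c(-c2ccccc2)[nH]c2ccccc12)C(=O)c1ccccc1` — 2000 nM
Compound 2 `COc1ccc(-c2[nH]c3ccc(OC)cc3c2/C=C(\C#N)S(=O)(=O)c2ccccc2)cc1` — 654 nM
Compound 3 `COc1ccc(-c2[nH]c3ccccc3c2/C=C(\C#N)S(=O)(=O)c2ccccc2)cc1` — 374 nM

In a functional assay on KM12 cells (Homo sapiens) for inhibition, read by sulforhodamine B assay, with a stated time of 48 h (a lower number here means a stronger inhibitor of growth, a higher number a weaker inhibitor of growth), compound 3 gives 374 nM, the lowest of the three numbers. Its nearest neighbour is compound 2, whose value of 654 nM lies within the scatter of it; compound 1, with 2000 nM, lies beyond the scatter but differs from compound 3 in more than one place, so its two values are only set side by side.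

Compound 4 `N#C/C(=C\c1c(-c2ccccc2)[nH]c2ccccc12)S(=O)(=O)c1ccccc1` is the next step: hydrogen in place of methoxy on an aromatic carbon. Among the compounds with values here, the one measured step of the same kind is a 1.7-fold lower number from compound 2 to compound 3 (0.24 log units; within the scatter), where the methoxy left a different aromatic carbon. That step was within the scatter, so the expectation for compound 4 in this assay is no shift beyond the scatter. Compound 4 is estimated at 400 nM, with a range from 150 nM to 1100 nM. The step this implies, a 1.1-fold higher number from compound 3 to compound 4 (0.03 log units; within the scatter), is expected to stay inside the usual scatter.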

Compound 4, concentration for 50% growth inhibition: 652 nM
Compound 4: the middle estimate sits 1.6-fold (0.21 log units) below what was measured; the measured number falls inside the stated range.
By their numbers in this assay, from the lowest: compounds 3, 4 and 2 (each within the scatter of the next); then compound 1.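

In this assay the change from 4-methoxyphenyl to phenyl gives a 1.7-fold higher number from compound 3 to compound 4 (0.24 log units; within the scatter), so removing this methoxy stays within the scatter, as did removing the methoxy on the other aromatic carbon, a 1.7-fold lower number from compound 2 to compound 3 (0.24 log units; within the scatter). Within the data shown here, the same compound 4 also gives the first single-place comparison at the double-bonded chain carbon: phenylsulfonyl in place of benzoyl gives a 3.1-fold lower number from compound 1 to compound 4 (0.49 log units; beyond the scatter), a modest change but the only one of these steps beyond the scatter. Nothing available explains either result.

The compounds shown leave open whether an amine, a carboxylic acid or a longer chain in place of the methoxy on the 4-methoxyphenyl group would move the number beyond the scatter. They also leave open whether a carboxylic acid or an amide in place of phenylsulfonyl would keep the number of compound 4.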